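The source may hold more compounds than are shown below. What is called first, only, known or untested is meant among the compounds shown, and "the series" means these compounds.

In an ADME assay on Raji cells (Homo sapiens) for cytotoxicity, read by CellTiter-Glo and resazurin assay, with a stated time of 72 h (a lower number here means that less compound is needed, a higher number that more compound is needed for the effect), compound 3 `CCOC(=O)CCCCCOc1cccc(CN(C(=O)c2ccc(-c3cccc(OC(C)C)c3)cc2)C(C)C)c1` gives only a limit of > 26000 nM. Its two measured neighbours fare the same way. Compound 1 `CC(C)Oc1cccc(-c2ccc(C(=O)N(Cc3cccc(OCCCCCC(=O)O)c3)C(C)C)cc2)c1` gives only a limit of > 26000 nM in this assay. Compound 2 `CCOC(=O)CCCCCOc1cccc(CN(C(=O)c2ccccc2)C(C)C)c1` likewise gives only a limit of > 26000 nM. The steps a step that the two limits leave unreadable from compound 1 to compound 3 and a step that the two limits leave unreadable from compound 2 to compound 3 therefore cannot be sized, because of the limit of > 26000 nM in this assay, at which 3 of the 3 values shown sit. Neither of them tells how far compound 3 really lies beyond that limit.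

Compound 4 `CCOC(=O)CCCCCOc1cccc(CN(C(=O)c2ccc(-c3cccc(O)c3)cc2)C(C)C)c1` differs from compound 3 by hydrogen in place of isopropyl on an oxygen on an aromatic ring. Within the data shown here, no measured step removes the same group, and the two steps that reach compound 3 are unreadable, so the only guide is that every compound measured so far sits at the limit (the limit of > 26000 nM in this assay, at which 3 of the 3 values shown sit). From compound 3 to compound 4 the expected step in this assay is a step that the limit leaves unreadable from compound 3 to compound 4, that is, nothing that the assay would resolve. For compound 4 the estimate in this assay is 30000 nM, between 15000 nM and 80000 nM, with a high chance that only a limit is reported again.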

Compound 4, half-maximal effective concentration: > 26000 nM
Compound 4 ended at the assay's limit (the forecaster's own chance of this, stated with the estimate: 80%); the middle value is on the limit's open side.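

Compound 4 also gives only a limit, so neither its step from compound 3 nor its step from compound 2 can be read: the limit of > 26000 nM in this assay, at which 4 of the 4 values shown sit.

The compounds shown leave open how far each lies beyond that limit in this assay, and whether hydroxy in place of isopropoxy changes anything there.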